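Swapping the sulfonyl aryl group of compound 3 for a dimethylphenyl

The compounds below may be only part of what the source reports. "The series", "measured", "known", "first", "only" and "open" are said of these compounds alone.

Compound 3, with structure `CC1CCN(c2c(S(=O)(=O)c3ccc(F)c(Cl)c3)cnc3cc(F)ccc23)CC1`, carries a 3-chloro-4-fluorophenyl on the sulfonyl sulfur. In an assay on isolated protein for displacement of a labelled ligand from metabotropic glutamate receptor 5 (Homo sapiens), with a stated time of 60 min, tested at 1 uM (a higher number here means more inhibition at the concentration tested (going by the name of the read-out), a lower number less inhibition), compound 3 gives 94%, the highest of the three numbers shown, though its gap to compound 1 is within the scatter. Compound 1, with structure `Cc1ccc(S(=O)(=O)c2cnc3ccc(Cl)cc3c2N2CCC(C)CC2)cc1C` and a 3,4-dimethylphenyl on the sulfonyl sulfur together with a chlorine on its core, gives 84%. Compound 2, with structure `CC1CCN(c2c(S(=O)(=O)c3ccc(C#N)cc3)cnc3cc(F)ccc23)CC1`, gives 83%.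

Compound 4, with structure `Cc1cc(C)cc(S(=O)(=O)c2cnc3cc(F)ccc3c2N2CCC(C)CC2)c1`, differs from compound 3 as follows: 3,5-dimethylphenyl in place of 3-chloro-4-fluorophenyl on a sulfonyl sulfur. Within the data shown here, the only measured step at this position is a number 11 percentage points higher from compound 2 to compound 3 (beyond the scatter), a modest move despite a complete change of aryl substituent. Among the measured compounds shown here, compound 1, which bears a different dimethylphenyl on a different core, is within the scatter of compound 3, and no step is computed between them. The expectation is therefore a change no larger than the scatter, a number 8 percentage points lower from compound 3 to compound 4 (within the scatter), so compound 4 is estimated at 86%, within 72% to 97%.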

Compound 4, a percentage reported as inhibition, at one concentration (the size of the read-out at that concentration, not a potency): 80%
The estimate for compound 4 lay 6 percentage points above the measured number; the range from low to high includes it.
By their numbers in this assay, from the lowest: compounds 4, 2, 1 and 3 (each within the scatter of the next, the first and the last beyond it).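

In this assay, the aryl group on the sulfonyl sulfur matters even when the heavy-atom count stays the same, as 3,5-dimethylphenyl in place of 3-chloro-4-fluorophenyl gives a number 14 percentage points lower from compound 3 to compound 4 (beyond the scatter). Replacing 4-cyanophenyl with 3,5-dimethylphenyl gives a number 3 percentage points lower from compound 2 to compound 4 (within the scatter), so on this shared core these two groups cannot be told apart, and only 3-chloro-4-fluorophenyl stands clear of both. Nothing available explains why the groups differ in this way.

The compounds shown leave open whether the chlorine, the fluorine or the two together account for the higher number of compound 3. They also leave open how an aryl group carrying an amine or a carboxylic acid would behave at this sulfonyl sulfur.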